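Replacing the chain group of compound 3

A few compounds are considered here, and "the series" means these few. Any claim that something is new, unique, unknown or untested is made for them only; others in the source may bear on it.

In an ADME assay for permeability, using PAMPA, with a stated time of 4 h, at pH 5.5 (a higher number here means that the compound crosses the layer faster, a lower number that the compound crosses the layer more slowly), compound 2 `CN(C[C@H]1Cc2ncccc2CN1)[C@H]1CCCc2cccnc21` gives 460 nm/s, compound 3 `NC(=O)NC/C=C\CN(C[C@H]1Cc2ncccc2CN1)[C@H]1CCCc2cccnc21` gives 5 nm/s and compound 1 `NCCCCN(C[C@H]1Cc2nccnc2CN1)[C@H]1CCCc2cccnc21` gives 2 nm/s. Compound 3 is therefore second of the three, far under compound 2 and a little over compound 1. Compound 4 `CN(CCCCN(C[C@H]1Cc2ncccc2CN1)[C@H]1CCCc2cccnc21)C1CCOCC1` differs from compound 3 by one change: a group of 11 heavy atoms (9 carbon, 1 nitrogen, 1 oxygen; one six-membered non-aromatic ring with 1 hetero atom) in place of a group of 7 heavy atoms (4 carbon, 2 nitrogen, 1 oxygen; no ring), on a saturated chain carbon bound to an amine nitrogen. Going by the values given here, the only measured step that bears on it is large, a 92-fold lower number from compound 2 to compound 3 (1.96 log units; beyond the scatter), but it starts from a hydrogen atom, and no measured step swaps one group for another. With both groups being sizeable, no step beyond the scatter is expected, and no direction is favoured. The expected step is a 1.2-fold higher number from compound 3 to compound 4 (0.08 log units; within the scatter). For compound 4 the estimate is 6 nm/s, with an expected range of 1.5 nm/s to 30 nm/s.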

Compound 4, apparent permeability: 15 nm/s
Compound 4: the middle estimate sits 2.5-fold (0.40 log units) below what was measured; the measured number falls inside the stated range.
By their numbers in this assay, from the lowest: compound 1; then compound 3; then compound 4; then compound 2.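

In this assay, exchanging one sizeable group for another on a saturated chain carbon bound to an amine nitrogen still moves the number, with a 3.0-fold higher number from compound 3 to compound 4 (0.48 log units; beyond the scatter). That step is modest beside the one from the hydrogen atom, as the group with the six-membered non-aromatic ring still leaves a 31-fold lower number from compound 2 to compound 4 (1.49 log units; beyond the scatter). No supporting measurement ties the step to any feature of either group. On these data alone, whether the ring, the hydrogen-bond donors leaving or the double bonds leaving carry the step remains open. Also open, as far as these compounds go, is how a morpholine or a carboxylic acid at this place would compare with compound 4.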